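Swapping a sulfamoyl group for a dimethylurea

The source may hold more compounds than are shown below. What is called first, only, known or untested is meant among the compounds shown, and "the series" means these compounds.

Compound 1 `CN(C[C@@H]1CCCc2cc(S(=O)(=O)c3cccc(F)c3)ccc21)S(N)(=O)=O` gives 3.98 nM in an assay on isolated protein for displacement of a labelled ligand from 5-hydroxytryptamine receptor 6 (Homo sapiens) (on this read-out lower numbers stand for stronger inhibition and higher numbers for weaker inhibition), the second highest of the three numbers shown. Compound 2 `O=C(NC[C@@H]1CCCc2cc(S(=O)(=O)c3cccc(F)c3)ccc21)c1ccc[nH]1` gives 5.01 nM, and compound 3 `COCCNC[C@@H]1CCCc2cc(S(=O)(=O)c3cccc(F)c3)ccc21` gives 0.251 nM. Compound 4 `CN(C)C(=O)NC[C@@H]1CCCc2cc(S(=O)(=O)c3cccc(F)c3)ccc21` differs from compound 1 by (dimethylcarbamoyl)amino in place of methyl(sulfamoyl)amino on a saturated chain carbon bound to a saturated ring carbon. For the measured compounds named here, two measured steps bear on this change. The step of a 1.3-fold higher number from compound 1 to compound 2 (0.10 log units; within the scatter) exchanged one neutral group carrying a hydrogen-bond donor for another and changed little. The step of a 16-fold lower number from compound 1 to compound 3 (1.20 log units; beyond the scatter) was large, but it brought in (2-methoxyethyl)amino, an amine without a carbonyl or sulfonyl, whereas compound 4 keeps a carbonyl-bearing donor much like compound 2. Compound 4 is therefore expected to give 5 nM, in the range 1.5 nM to 16 nM. For compound 4 this estimate means a step of a 1.3-fold higher number from compound 1 to compound 4 (0.10 log units; within the scatter).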

Compound 4, inhibition constant: 2.51 nM
Compound 4: middle estimate off by 2.0-fold (0.30 log units), on the high side; the measured number falls inside the stated range.
By their numbers in this assay, from the lowest: compound 3; then compounds 4, 1 and 2 (each within the scatter of the next).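

In this assay, the result shows that this position accepts a urea as well as a sulfamoyl group or a pyrrole amide: a 1.6-fold lower number from compound 1 to compound 4 (0.20 log units; within the scatter) and a 2.0-fold lower number from compound 2 to compound 4 (0.30 log units; within the scatter) both stay within the scatter. Compound 3 stands apart from this group, with a 10-fold higher number from compound 3 to compound 4 (1.00 log units; beyond the scatter) lying beyond the scatter. Nothing given here explains either finding. From the compounds shown here alone, it remains open whether an acetyl or methanesulfonyl group on the same nitrogen would read like compound 4. Going by these compounds, it also remains open whether a simple ethyl or a longer chain ending in a hydroxyl group would match compound 3.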